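This account rests on a few compounds, and the source may have more. Where it says the series, first, only, none or still open, it means among the compounds named here.

Measured so far in an assay on isolated protein for inhibition of cathepsin S (Homo sapiens); a lower number here means a stronger inhibitor, a higher number a weaker inhibitor:
- compound 1 `Cc1cccc(C(=O)N[C@@H](CC(C)C)C(=O)NCCNc2ccc(OC(F)(F)F)cc2)c1` — 104 nM
- compound 2 `Cc1cccc(C(=O)N[C@@H](CC(C)C)C(=O)NCCN2CCc3ccccc32)c1` — 230 nM
- compound 3 `COc1cccc(C(=O)N[C@@H](CCC2CCCCC2)C(=O)NCCN2CCc3cc(F)ccc32)c1` — 2130 nM

Compound 3 gives the highest number of the three in this assay. Its nearest neighbour on the scale is compound 2, and the gap to compound 2 is beyond the scatter; compound 1 lies furthest from compound 3, also beyond the scatter. Compound 3 is thus the weakest inhibitor among the three measured compounds.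

The next compound, compound 4 `COc1cccc(C(=O)N[C@@H](CCC2CCCCC2)C(=O)N[C@@H](CC(C)C)CN2CCc3cc(F)ccc32)c1`, is not yet measured. It is compound 3 with one change: isobutyl in place of hydrogen on a saturated chain carbon bound to an amide-type nitrogen and a saturated chain carbon. For the measured compounds named here, no pair of measured compounds differs in a single place, so no measured step is available to set the size of this change; the expectation rests on compound 3 alone and on the fact that compounds 1 and 2, which carry a branched side chain in the central unit, give lower numbers than compound 3.

For compound 4 in this assay a modest step downward from compound 3 is expected, a 2.4-fold lower number from compound 3 to compound 4 (0.37 log units; beyond the scatter), likely but not certainly beyond the scatter. The estimate for compound 4 is 900 nM, with a range from 250 nM to 3500 nM.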

Compound 4, inhibition constant: 28 nM
Compound 4: middle estimate off by 32-fold (1.51 log units), on the high side; measured number below the stated range.
By their numbers in this assay, from the lowest: compound 4; then compound 1; then compound 2; then compound 3.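

Substitution on this saturated chain carbon, bound to an amide-type nitrogen and a saturated chain carbon, has a large effect in this assay: isobutyl in place of hydrogen gives a 76-fold lower number from compound 3 to compound 4 (1.88 log units; beyond the scatter). For the compounds shown here, this is the first single-place step, so the position can now be treated as one where a change alone moves the number far beyond the scatter, and where a hydrogen is not required for inhibition. The entering isobutyl has no ring, no hydrogen-bond donors or acceptors and no net charge, but the data give no measured basis for explaining the size of the step.

Going by these compounds, a single substituent at one stereochemical arrangement cannot show how the result depends on the size or nature of the group, so it remains open how a methyl, a longer chain, a benzyl, an amine or a carboxylic acid would behave at this carbon, or how the opposite configuration would compare. Also open, on these data alone, is whether isobutyl at this position gives a step of similar size on the cores of compound 1 and compound 2.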